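The source may report more compounds than this note shows. Statements on the series, on what has been measured and on what is new or still open speak of the compounds shown alone.

Compound 1 `O=C(Nc1nnc(C2CCCC2)s1)c1ccc2c(c1)OCCO2` carries a cyclopentyl group on its core. Among the measured compounds shown here, in an in vivo ADME assay on the whole organism (strain Sprague-Dawley) for pharmacokinetics, with Rattus norvegicus as the target, at a dose of 2 mg/kg by the oral route (a lower number here means that a smaller share of the oral dose reaches the circulation, a higher number that a larger share of the oral dose reaches the circulation), compound 1 gives 14%, the lowest of the two numbers measured so far. For the measured compounds named here, compound 2 `O=C(Nc1nnc(-c2c(Cl)cccc2Cl)s1)c1ccc2c(c1)NCCO2` differs from compound 1 in more than one place, so no single step connects the two; in this assay compound 2 gives 70%, which lies beyond the usual scatter above the number for compound 1. Compound 3 `Cc1cc(C)c(-c2nnc(NC(=O)c3ccc4c(c3)OCCO4)s2)c(C)c1` is the unmeasured compound. The change from compound 1 to compound 3 is 2,4,6-trimethylphenyl in place of cyclopentyl on an aromatic carbon. Going by the values given here, no measured pair shows this change on its own, so its size cannot be read from the data and has to be guessed. Compound 2, which also carries an aromatic ring on its core, gives 70%, and this is the only hint available. Compound 3 is therefore expected to move upward, with an estimated step of a number 16 percentage points higher from compound 1 to compound 3 (beyond the scatter). The estimate for compound 3 in this assay is 30%, with a range from 8% to 60%.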

Compound 3, oral bioavailability: 65%
Beside the measured number, compound 3's estimate is 35 percentage points below it, and the stated range ends below it.
By their numbers in this assay, from the lowest: compound 1; then compounds 3 and 2 (each within the scatter of the next).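

In this assay, among the compounds shown here, swapping cyclopentyl for 2,4,6-trimethylphenyl gives the first reading of a single change at this position, the aromatic carbon next to the ring nitrogen and next to the ring sulfur, and the change is large (a number 51 percentage points higher from compound 1 to compound 3 (beyond the scatter)). With the rest of the molecule held the same, the group on this one carbon can by itself separate a small oral share reaching the circulation from a much larger one, which the earlier pair could not show, as those two compounds differ in more than one place. Nothing available explains why the number rises, so the step stands as an observation without a known cause.

From the compounds shown here alone, with only these two groups compared at this carbon, it stays open whether the rise needs the three methyl groups of 2,4,6-trimethylphenyl or would also come with a plain phenyl ring. An amine, a carboxylic acid or a longer carbon chain on the same carbon would show how widely the number follows the group placed there.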